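Trimming a Long Side Chain on a Nucleoside Core

The source may report more compounds than this note shows. Statements on the series, on what has been measured and on what is new or still open speak of the compounds shown alone.

Of the compounds shown here, two sharing one core have been measured in a functional assay (B cells) with Mus musculus as the target; on this read-out lower numbers stand for an effect already at smaller amounts and higher numbers for an effect only at larger amounts of compound. Compound 1, `Nc1nc(O)c2c(n1)n(C1OC(CO)[C@@H](O)[C@H]1O)c(=O)n2CC(O)CSc1ccccc1`, gives 142 uM. Compound 2, `C=CCn1c(=S)n(C2OC(CO)[C@@H](O)C(O)[C@H]2O)c2nc(N)nc(O)c21`, gives 1 uM in this assay. Within the data shown here, on these two numbers compound 1 stands highest, and its gap to compound 2 lies well beyond the usual scatter; no single structural step between the two has been worked out, so the gap can only be noted, not traced to one change.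

Compound 3, `CCOC(=O)Cn1c(=O)n(C2OC(CO)[C@@H](O)[C@H]2O)c2nc(N)nc(O)c21`, differs from compound 1 in one place: ethoxycarbonyl in place of 1-hydroxy-2-(phenylsulfanyl)ethyl on a saturated chain carbon bound to an aromatic nitrogen. Among the measured compounds shown here, no measured pair shows the effect of this change. Still, the side chain of compound 1 is the longest among the measured compounds, so a moderate move toward lower numbers is expected: a step of a 2.8-fold lower number from compound 1 to compound 3 (0.45 log units; beyond the scatter) is estimated, somewhat beyond the scatter but far from the gap to compound 2. Compound 3 is therefore expected to give about 50 uM, likely between 8 uM and 300 uM.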

Compound 3, concentration for half-maximal effect: 48 uM
Compound 3: middle estimate off by 1.0-fold (0.02 log units), on the high side; the range from low to high includes it.
By their numbers in this assay, from the lowest: compound 2; then compound 3; then compound 1.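

Among these compounds, this is the first measured step at this position: in this assay, ethoxycarbonyl in place of 1-hydroxy-2-(phenylsulfanyl)ethyl on a saturated chain carbon bound to an aromatic nitrogen gives a 3.0-fold lower number from compound 1 to compound 3 (0.47 log units; beyond the scatter), a modest change. The position therefore responds to the group it carries, and the lower number comes with fewer heavy atoms, with no ring and no sulfur. No available measurement ties this step to any single feature of either group.

The change alters several features at once, leaving open whether the phenyl ring, the sulfur, the hydroxy group or the ester matters most. Also open, from the compounds shown here alone, is how a carboxylic acid, an amine or a plain ethyl chain would read at this place.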